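Ester variation on the shared core: stability notes

The source may hold more compounds than are shown below. What is called first, only, known or untested is meant among the compounds shown, and "the series" means these compounds.

Measured compounds:
compound 1 `C[C@@H](O)[C@H]1C(=O)N2C(C(=O)OCOC(=O)C(C)(C)C)=C(S[C@@H]3CN[C@H](C(=O)Nc4cccc(C(=O)O)c4)C3)[C@H](C)[C@H]12`, in an ADME assay for metabolic stability, read by LC-MS, with a stated time of 3 h, at pH 6.5, tested at 50 uM; a higher number here means that more of the compound is left, a lower number that less of the compound is left: > 95%, a limit of the assay
compound 2 `C[C@@H](O)[C@H]1C(=O)N2C(C(=O)OCOC(=O)OC3CCCCC3)=C(S[C@@H]3CN[C@H](C(=O)Nc4cccc(C(=O)O)c4)C3)[C@H](C)[C@H]12`: > 95%, a limit of the assay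
compound 3 `C[C@@H](O)[C@H]1C(=O)N2C(C(=O)OCOC(=O)OC3CCCCC3)=C(S[C@@H]3CN[C@H](C(=O)Nc4cccc(C(=O)OCOC(=O)OC5CCCCC5)c4)C3)[C@H](C)[C@H]12`: > 95%, a limit of the assay

Compound 2 therefore stands at the limit, together with every other value shown (the limit of > 95% in this assay, at which 3 of the 3 values shown sit). The steps a step that the two limits leave unreadable from compound 1 to compound 2 and a step that the two limits leave unreadable from compound 2 to compound 3 give no readable size, since both ends sit at that limit.

Compound 4 `CCOC(=O)C1=C(S[C@@H]2CN[C@H](C(=O)Nc3cccc(C(=O)O)c3)C2)[C@H](C)[C@@H]2[C@@H]([C@@H](C)O)C(=O)N12` differs from compound 2 by methyl in place of (cyclohexyloxycarbonyl)oxy on a saturated chain carbon bound to an oxygen next to a carbonyl group. Among the compounds with values here, only the two unreadable steps touch an ester change of this kind, so no measured step gives a size to expect. Given that compound 2 stands at the limit (the limit of > 95% in this assay, at which 3 of the 3 values shown sit), compound 4 is expected to stay close to it as well. Compound 4 is estimated at 93%, between 78% and 99%. The expected step is a number at least 2 percentage points lower from compound 2 to compound 4 (that floor lies within the scatter), within the scatter.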

Compound 4, percent of the compound remaining: > 95%
Compound 4 gave a limit, no number; the forecaster's own chance of this, stated with the estimate: 65%; middle value at least 2 percentage points from the limit.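

The steps to compound 4 from compound 1 and from compound 2 cannot be read, because these compounds all sit at one limit: the limit of > 95% in this assay, at which 4 of the 4 values shown sit.

The compounds shown leave open whether their ester groups differ at all in this assay.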